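From tert-butyl to phenoxy on the aryl urea

The compounds below may be only part of what the source reports. "The series", "measured", "known", "first", "only" and "open" are said of these compounds alone.

For the measured compounds named here, in a functional assay on HEK293 cells for antagonist activity at transient receptor potential cation channel subfamily V member 1 (Rattus norvegicus) (on this read-out higher numbers stand for weaker inhibition and lower numbers for stronger inhibition), compound 2 `CC(C)(C)c1ccc(NC(=O)N2CCN(c3ncccc3C(F)(F)F)CC2)cc1` gives 57.7 nM, the lowest of the two numbers measured so far, while compound 1 `Cc1ccc(NC(=O)N2CCN(c3ncccc3C(F)(F)F)CC2)cc1` gives 1550 nM. Going by the values given here, the only measured step that bears on the next change, a 27-fold lower number from compound 1 to compound 2 (1.43 log units; beyond the scatter), was large and ran toward stronger inhibition. Compound 3 `O=C(Nc1ccc(Oc2ccccc2)cc1)N1CCN(c2ncccc2C(F)(F)F)CC1` carries phenoxy in place of tert-butyl on an aromatic carbon. Because that step a 27-fold lower number from compound 1 to compound 2 (1.43 log units; beyond the scatter) rewarded the tert-butyl so strongly, the phenoxy is expected to hold potency close to that level. Compound 3 is therefore estimated at 40 nM, within 8 nM to 200 nM, an expected step of a 1.4-fold lower number from compound 2 to compound 3 (0.16 log units; within the scatter) inside the scatter.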

Compound 3, half-maximal inhibitory concentration: 916 nM
The estimate for compound 3 lay 23-fold (1.36 log units) below the measured number, and the stated range ends below it.
By their numbers in this assay, from the lowest: compound 2; then compounds 3 and 1 (each within the scatter of the next).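

In this assay this position did not reward every group with more heavy atoms: phenoxy, which adds an aromatic ring and a hydrogen-bond acceptor, gave a 16-fold higher number from compound 2 to compound 3 (1.20 log units; beyond the scatter) and so gave up the gain seen with tert-butyl. The comparison with methyl, a 1.7-fold lower number from compound 1 to compound 3 (0.23 log units; within the scatter) and so within the scatter, leaves phenoxy not distinguishable from that small group. No evidence is available to explain this result. Going by these compounds, whether the ether oxygen or the added ring matters more stays open, as does how an isopropyl or a benzyl group would read here.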